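Cytotoxicity in a Biaryl Acid Series: Chloro to Methylsulfonyl

The compounds below may be only part of what the source reports. "The series", "measured", "known", "first", "only" and "open" are said of these compounds alone.

Compound 1 `CC(C)N(Cc1cccc(OCCCCCC(=O)O)c1)C(=O)c1ccc(-c2cccc(C(F)(F)F)c2)cc1` gives > 26000 nM as a limit of the assay. Compound 2 `CC(C)N(Cc1cccc(OCCCCCC(=O)O)c1)C(=O)c1ccc(-c2cccc(Cl)c2)cc1` gives > 21900 nM as a limit of the assay.

Both measured compounds were tested in an ADME assay on HEK293 cells (Homo sapiens) for cytotoxicity, read by CellTiter-Glo and resazurin assay, with a stated time of 72 h; a lower number here means that less compound is needed, a higher number that more compound is needed for the effect. Compound 2 sits at a limit (the limit of > 21900 nM in this assay, at which 1 of the 2 values shown sits), and compound 1 likewise sits at a limit (the limit of > 26000 nM in this assay, at which 1 of the 2 values shown sits); neither result is a number. Among the measured compounds shown here, the one measured step, a step that the two limits leave unreadable from compound 1 to compound 2, therefore cannot be read in size or direction.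

Compound 3 `CC(C)N(Cc1cccc(OCCCCCC(=O)O)c1)C(=O)c1ccc(-c2cccc(S(C)(=O)=O)c2)cc1` differs from compound 2 in a single place: methylsulfonyl in place of chloro on an aromatic carbon. For the measured compounds named here, no measured step bears on this change, and the only step available gives no size at all. There is thus no ground for expecting a readable change in this assay from compound 2 to compound 3 beyond the scatter, and the most likely outcome is that compound 3 also returns a limit.

Compound 3 is therefore estimated at 30000 nM, within a range of 10000 nM to 100000 nM, which is expected to mean a step that the limit leaves unreadable from compound 2 to compound 3.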

Compound 3, half-maximal effective concentration: > 26000 nM
Compound 3: no number, only a limit; the forecaster's own chance of this, stated with the estimate: 80%; the middle value lies beyond the limit too.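

In this assay compound 3 gives > 26000 nM, which is a limit of the assay and not a number. Among the compounds shown here, no step among compound 1, compound 2 and compound 3 can therefore be read, in size or direction. The compounds shown leave open whether trifluoromethyl, chloro and methylsulfonyl differ at all in their effect on these cells.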